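The source may hold more compounds than are shown below. What is called first, only, known or untested is meant among the compounds shown, and "the series" means these compounds.

Working notes on the series. In a functional assay on DU-145 cells (Homo sapiens) for inhibition, read by trypan blue exclusion, with a stated time of 96 h (a higher number here means a weaker inhibitor of growth, a lower number a stronger inhibitor of growth), compound 3 (`O=C(O)c1cc(/C=C(/Sc2ccc(Br)cc2)C(=O)c2c(F)c(F)c(F)c(F)c2F)ccc1O`) gives 25000 nM, and compound 1 (`O=C(/C(=C\c1ccc(O)c([N+](=O)[O-])c1)S(=O)(=O)Cc1ccc(Br)cc1)c1c(F)c(F)c(F)c(F)c1F`) gives 50000 nM, so the two lie within the scatter of each other. Compound 2 (`O=C(O)c1cc(/C=C(\C(=O)c2c(F)c(F)c(F)c(F)c2F)S(=O)(=O)c2ccc(Br)cc2)ccc1O`) reports only a limit, > 100000 nM.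

Compound 4 (`O=C(/C(=C\c1ccc([N+](=O)[O-])c(O)c1)Sc1ccc(Br)cc1)c1c(F)c(F)c(F)c(F)c1F`) keeps the (4-bromophenyl)sulfanyl group of compound 3 and differs on a double-bonded chain carbon bound to a double-bonded chain carbon: 3-hydroxy-4-nitrophenyl in place of 3-carboxy-4-hydroxyphenyl on a double-bonded chain carbon bound to a double-bonded chain carbon. Within the data shown here, the one measured step, an at least 4.0-fold lower number from compound 2 to compound 3 (0.60 log units; beyond the scatter), concerns the sulfanyl and sulfonyl exchange, so it gives no size for this change. Compound 1 also carries a nitro group and gives a number, 50000 nM, but differs elsewhere too.

The expected result is a 1.3-fold lower number from compound 3 to compound 4 (0.10 log units; within the scatter), with no shift beyond the scatter anticipated. For compound 4 the estimated value is 20000 nM, with an expected range of 6000 nM to 70000 nM.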

Compound 4, concentration for 50% growth inhibition: 1000 nM
Compound 4: middle estimate off by 20-fold (1.30 log units), on the high side; the whole stated range lies above it.
By their numbers in this assay, from the lowest: compound 4; then compounds 3 and 1 (each within the scatter of the next). At a limit, above all of these: compound 2.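

At this position, with the (4-bromophenyl)sulfanyl group held constant, this assay responds strongly to the aryl group: 3-hydroxy-4-nitrophenyl in place of 3-carboxy-4-hydroxyphenyl gives a 25-fold lower number from compound 3 to compound 4 (1.40 log units; beyond the scatter). Among these compounds, the earlier compounds gave a step only for the sulfanyl and sulfonyl exchange, so this is the first size for a change at this place. Nothing measured here bears on the reason for this step.

Still open, on these data alone, is which part of the exchange carries the step, the nitro group or the loss of the carboxylic acid. Also open, as far as these compounds go, is whether an amine in place of the nitro group would keep it.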